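The source may report more compounds than this note shows. Statements on the series, on what has been measured and on what is new or still open speak of the compounds shown alone.

Compound 1 `CN1CCN(c2nc3ccccc3n2CCOc2ccccc2)CC1` carries a methyl on the ring amine nitrogen and a phenoxyethyl chain on the shared core; in a functional assay on ileum for inhibition of histamine H1 receptor (Cavia porcellus) (on this read-out lower numbers stand for stronger inhibition and higher numbers for weaker inhibition), compound 1 gives 6.9 nM. Compound 2 `CCCN1CCN(c2nc3ccccc3n2CCOCC)CC1` carries a propyl on that nitrogen and an ethoxyethyl chain; in this assay compound 2 gives 16 nM, the higher of the two numbers given, and its gap to compound 1 lies beyond the scatter, though the two compounds differ in two places at once. Compound 3 `CCOCCn1c(N2CCN(C(c3ccccc3)c3ccccc3)CC2)nc2ccccc21` carries a far larger group on the ring amine nitrogen, and in this assay compound 3 reaches only a limit, > 3000 nM, which is one of the limits of the limit of > 3000 nM in this assay, at which 1 of the 3 values shown sits, rather than a number.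

Compound 4 `CCCCCN1CCN(c2nc3ccccc3n2CCOCC)CC1` differs from compound 2 by ethyl in place of hydrogen on a saturated chain carbon, three bonds along the chain from an amine nitrogen in a ring. Within the data shown here, no measured pair isolates a change of this kind, so the expected step from compound 2 to compound 4 in this assay is set as a modest weakening, a 2.2-fold higher number from compound 2 to compound 4 (0.34 log units; beyond the scatter), not far beyond the scatter. Compound 4 is therefore estimated at 35 nM in this assay, with a range from 10 nM to 150 nM.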

Compound 4, half-maximal inhibitory concentration: 30 nM
The estimate for compound 4 lay 1.2-fold (0.07 log units) above the measured number; the measured number falls inside the stated range.
By their numbers in this assay, from the lowest: compound 1; then compounds 2 and 4 (each within the scatter of the next). At a limit, above all of these: compound 3.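

In this assay, among these compounds, the change from propyl to pentyl on the ring amine nitrogen, the first change here seen on its own, gives a 1.9-fold higher number from compound 2 to compound 4 (0.27 log units; within the scatter) and shows that this position accepts a pentyl chain without a change beyond the scatter. In this assay compound 3, with its far larger group on that nitrogen, sits at a limit, > 3000 nM and not at a number. Nothing shown gives a reason for the size of this step.

On these data alone, what stays open is how a hexyl or longer chain, or a chain ending in an amine or a carboxylic acid, would fare on that nitrogen. Also open, as far as these compounds go, is what the phenoxyethyl chain of compound 1 contributes alone, since compound 1 differs from compound 2 in two places.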